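Hydroxyphenyl placement in the pyridine series: compound 3 to compound 4

This account rests on a few compounds, and the source may have more. Where it says the series, first, only, none or still open, it means among the compounds named here.

Measured so far in a functional assay on T47D cells (Homo sapiens) for inhibition; on this read-out higher numbers stand for weaker inhibition and lower numbers for stronger inhibition:
- compound 1 `Oc1cccc(-c2cc(-c3cccc(F)c3)cc(-c3ccccc3O)n2)c1`, a limit of the assay: > 50000 nM
- compound 2 `Oc1cccc(-c2cc(-c3ccc(F)cc3)cc(-c3ccccc3O)n2)c1`, a limit of the assay: > 50000 nM
- compound 3 `Oc1ccccc1-c1cc(-c2ccccc2C(F)(F)F)cc(-c2ccccc2O)n1`: 22500 nM

Among the compounds with values here, compound 3 is the only member of the set with a number; compound 1 and compound 2 each return only a limit, as the limit of > 50000 nM in this assay, at which 2 of the 3 values shown sit, records. Within the data shown here, the one step between measured compounds, a step that the two limits leave unreadable from compound 1 to compound 2, is unreadable, since both ends are limits. It therefore says nothing usable about the size of any change in this series.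

Compound 4 `Oc1cccc(-c2cc(-c3ccccc3C(F)(F)F)cc(-c3ccccc3O)n2)c1` differs from compound 3 by 3-hydroxyphenyl in place of 2-hydroxyphenyl on an aromatic carbon. Among the measured compounds shown here, no measured step covers this exact change. What the set does show is that the two compounds carrying a 3-hydroxyphenyl, compound 1 and compound 2, both sit at the limit, while compound 3, with two 2-hydroxyphenyl groups, gives a number. On that basis compound 4 is expected to lose rather than gain, with a fair chance of reaching the limit again; the expected step is a 2.0-fold higher number from compound 3 to compound 4 (0.30 log units; within the scatter).

Compound 4 is estimated at 45000 nM, within a range of 15000 nM to 120000 nM.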

Compound 4, half-maximal inhibitory concentration: 5680 nM
Compound 4: middle estimate off by 7.9-fold (0.90 log units), on the high side, outside the stated range (below it).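

Moving the hydroxyl on the ring next to the ring nitrogen matters in this assay: 3-hydroxyphenyl in place of 2-hydroxyphenyl gives a 4.0-fold lower number from compound 3 to compound 4 (0.60 log units; beyond the scatter), so the 3-hydroxyphenyl group does not by itself bring the series to the limit, as compound 1 and compound 2 had suggested. With 3-hydroxyphenyl held in place, the other aryl group proves decisive, with 2-(trifluoromethyl)phenyl in place of 4-fluorophenyl giving an at least 8.8-fold lower number from compound 2 to compound 4 (0.94 log units; beyond the scatter), and 2-(trifluoromethyl)phenyl in place of 3-fluorophenyl giving an at least 8.8-fold lower number from compound 1 to compound 4 (0.94 log units; beyond the scatter). These two sizes are lower bounds only, since compound 1 and compound 2 each return a limit and not a number: the limit of > 50000 nM in this assay, at which 2 of the 4 values shown sit.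

The compounds shown leave open whether the gain from 3-hydroxyphenyl holds with a fluorophenyl group in place of 2-(trifluoromethyl)phenyl, since no fluorophenyl pair differing only in the hydroxyl placement is shown. They also leave open whether the hydroxyl itself is needed, which a methoxy group or an amine at the same place on that ring would test.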